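Swapping a chlorine-bearing ring for a methyl-bearing one

The source may hold more compounds than are shown below. What is called first, only, known or untested is meant among the compounds shown, and "the series" means these compounds.

Compound 1 `N#Cc1ccc(Nc2nc(Oc3ccccc3Cl)c3ccccc3n2)cc1` is the starting point. In an ADME assay on MT4 cells (Homo sapiens) for cytotoxicity, read by MTT assay, with a stated time of 4 days (on this read-out higher numbers stand for lower toxicity in this test and lower numbers for higher toxicity in this test), compound 1 gives 38000 nM. Among the three measured compounds it holds the second highest number: compound 2 `CCCOc1cc(C#N)cc(OC)c1Oc1nc(Nc2ccc(C#N)cc2)nc2ccccc12` gives 5200 nM, and compound 3 `CCCOc1cc(C#N)cc(OCC)c1Oc1nc(Nc2ccc(C#N)cc2)nc2ccccc12` gives 123000 nM, so compound 1 lies between them, nearer to compound 3. Within the data shown here, the only single-point step among the measured compounds is a 24-fold higher number from compound 2 to compound 3 (1.37 log units; beyond the scatter), a change at a different place from the one altered here. Compound 4 `Cc1cccc(Oc2nc(Nc3ccc(C#N)cc3)nc3ccccc23)c1` differs from compound 1 by 3-methylphenyl in place of 2-chlorophenyl on an oxygen on an aromatic ring. Among the measured compounds shown here, no measured step touches the oxygen on the aromatic ring where this swap happens, so the step from compound 2 to compound 3 gives no direct guide; it only shows that a small change elsewhere can move this number a great deal. With nothing pointing in either direction, the expected step is a 1.1-fold higher number from compound 1 to compound 4 (0.02 log units; within the scatter), that is, none beyond the scatter. Compound 4 is therefore estimated at 40000 nM, with a range from 12000 nM to 130000 nM.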

Compound 4, half-maximal cytotoxic concentration: 355000 nM
Compound 4: the middle estimate sits 8.9-fold (0.95 log units) below what was measured; the measured number lies above the stated range.
By their numbers in this assay, from the lowest: compound 2; then compound 1; then compound 3; then compound 4.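

On the oxygen on an aromatic ring, putting 3-methylphenyl in place of 2-chlorophenyl gives, in this assay, a 9.3-fold higher number from compound 1 to compound 4 (0.97 log units; beyond the scatter), a rise beyond the usual scatter that points to lower toxicity in this test. The earlier compounds shown here showed a change of this read-out only on a saturated chain carbon, whereas this step shows that the number also responds to the ring on this oxygen, even though both groups hold 7 heavy atoms. Nothing measured here bears on why the number rises.

The swap removes chlorine, adds methyl and alters the numbered ring position all at once, so the compounds shown cannot separate these three changes. A plain phenyl, 3-chlorophenyl or 2-methylphenyl on the same oxygen would pull them apart, and an amine on this ring remains an open case.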